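The source may hold more compounds than are shown below. What is called first, only, known or untested is meant among the compounds shown, and "the series" means these compounds.

Compound 1 `O=C(CSc1nc(Nc2ccccc2)c2ccccc2n1)Nc1cccc(F)c1` in a functional assay on MDA-MB-231 cells (Homo sapiens) for inhibition, read by MTT assay, with a stated time of 72 h (a higher number here means a weaker inhibitor, a lower number a stronger inhibitor), gives > 50000 nM, which is a limit of the assay rather than a number (the limit of > 50000 nM in this assay, at which 1 of the 3 values shown sits).
Compound 2 `O=C(CSc1nc(Nc2ccccc2)c2ccccc2n1)Nc1cccc(Cl)c1` in this assay gives 16500 nM.
Compound 3 `COc1cccc(NC(=O)CSc2nc(Nc3ccccc3)c3ccccc3n2)c1` in this assay gives 21700 nM.

Compound 3 stands with the highest of the two numbers shown in this assay, but its nearest neighbour is compound 2, and the step of a 1.3-fold higher number from compound 2 to compound 3 (0.12 log units; within the scatter) lies within the scatter, so the two cannot be ordered. Against compound 1 both stand apart: an at least 3.0-fold lower number from compound 1 to compound 2 (0.48 log units; beyond the scatter) and an at least 2.3-fold lower number from compound 1 to compound 3 (0.36 log units; beyond the scatter) are each beyond the scatter.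

Compound 4 `O=C(CSc1nc(Nc2ccccc2)c2ccccc2n1)Nc1ccc(Br)cc1` differs from compound 3 by 4-bromophenyl in place of 3-methoxyphenyl on an amide-type nitrogen. Going by the values given here, no measured step exchanges a substituent placed as in compound 4, so the halogen steps from compound 1 stand as the only guide, and they show the chloro and methoxy compounds close together. Compound 4 is therefore expected to land near compound 2 and compound 3, with the step of a 1.4-fold lower number from compound 3 to compound 4 (0.16 log units; within the scatter) estimated to stay within the scatter. The estimate for compound 4 in this assay is 15000 nM, with a range from 5000 nM to 50000 nM.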

Compound 4, half-maximal inhibitory concentration: 11500 nM
Estimate against measurement, compound 4: 1.3-fold (0.12 log units) above; low and high end bracket the measured number.
By their numbers in this assay, from the lowest: compounds 4, 2 and 3 (each within the scatter of the next). At a limit, above all of these: compound 1.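

In this assay, 4-bromophenyl on the amide-type nitrogen gives a number that cannot be told apart from those of the 3-methoxyphenyl and 3-chlorophenyl compounds: a 1.9-fold lower number from compound 3 to compound 4 (0.28 log units; within the scatter) and a 1.4-fold lower number from compound 2 to compound 4 (0.16 log units; within the scatter). Going by these compounds alone, this position therefore tolerates a change of both the group and its place on the ring without a step beyond the scatter, and only the step of an at least 4.3-fold lower number from compound 1 to compound 4 (0.63 log units; beyond the scatter) stands clear of it. Compound 1 remains a limit of the assay rather than a number: the limit of > 50000 nM in this assay, at which 1 of the 4 values shown sits.

The compounds shown do not separate the identity of the substituent from its place on the ring. From the compounds shown here alone, what an amine or a carboxylic acid on this phenyl ring, or a longer chain in place of the ring, would do in this assay remains open.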